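Swapping the aryl group on the piperazine nitrogen

The source may report more compounds than this note shows. Statements on the series, on what has been measured and on what is new or still open speak of the compounds shown alone.

Measured compounds:
compound 1, `COc1cc(OC)cc(N2CCN(C(=O)c3oc(C)nc3-c3cccc(F)c3)CC2)c1`, 28.2 nM
compound 2, `Cc1nc(-c2ccccc2F)c(C(=O)N2CCN(c3cc(Cl)cc(Cl)c3)CC2)o1`, 60.2 nM
compound 3, `COc1cccc(N2CCN(C(=O)c3oc(C)nc3-c3cccc(F)c3)CC2)c1`, "not active" (no number reported)

All three share one core and differ in the aryl group on the amine nitrogen in a ring. In a functional assay on HL-60 cells (Homo sapiens) for inhibition, read by MTT assay, with a stated time of 72 h (a higher number here means a weaker inhibitor, a lower number a stronger inhibitor), compound 1 gives 28.2 nM. In this assay compound 2 gives 60.2 nM. Compound 3 stands apart: in this assay compound 3 is reported as "not active" (no number reported), so no single number is known for it, and it cannot be placed against the other two on a scale.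

Compound 4, `Cc1nc(-c2cccc(F)c2)c(C(=O)N2CCN(c3cc(Cl)cc(Cl)c3)CC2)o1`, has not yet been measured. It differs from compound 3 in one place: 3,5-dichlorophenyl in place of 3-methoxyphenyl on an amine nitrogen in a ring. Compound 2 already carries the 3,5-dichlorophenyl group, and compound 2 gives 60.2 nM in this assay. No step size can be computed from compound 3, since its result carries no number. The author therefore expects compound 4 to land near compound 2, and estimates 45 nM for compound 4 in this assay, within 12 nM to 180 nM.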

Compound 4, half-maximal inhibitory concentration: 41.7 nM
The estimate for compound 4 lay 1.1-fold (0.03 log units) above the measured number, within the range that was stated.
By their numbers in this assay, from the lowest: compounds 1, 4 and 2 (each within the scatter of the next, the first and the last beyond it).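

In this assay compound 4, with 3,5-dichlorophenyl on the amine nitrogen in a ring, has a measured number, whereas compound 3, with 3-methoxyphenyl there, is reported as not active, so the step between them cannot be read as a size. Putting 3,5-dichlorophenyl in place of 3,5-dimethoxyphenyl gives a 1.5-fold higher number from compound 1 to compound 4 (0.17 log units; within the scatter), so these two groups are not told apart at this position. Putting 3-fluorophenyl in place of 2-fluorophenyl on an aromatic carbon gives a 1.4-fold lower number from compound 2 to compound 4 (0.16 log units; within the scatter), so this change does not tell compounds apart either.

Nothing shown explains why compound 3 alone has no number. On these data alone, it remains open whether a phenyl group bearing a single chlorine, or a trifluoromethyl group in place of the chlorines, would give a number in this assay.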